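Pyridin-3-yl for 4-methoxyphenyl on the ether chain

A few compounds are considered here, and "the series" means these few. Any claim that something is new, unique, unknown or untested is made for them only; others in the source may bear on it.

Compound 1, `COc1ccc(CCOc2ccc(-c3c(C)nc(C)c([C@H](OC(C)(C)C)C(=O)O)c3N3CCC(C)(C)CC3)cc2)cc1`, is tested in an ADME assay on microsomes from liver (Homo sapiens) for metabolic stability, read by LC-MS, tested at 0.5 uM (a lower number here means that the compound disappears faster, a higher number that the compound lasts longer), where compound 1 reaches only the limit of > 2 h, so no number is known for it. Compound 2, `Cc1nc(C)c([C@H](OC(C)(C)C)C(=O)O)c(N2CCC(C)(C)CC2)c1-c1ccc(OCCc2cc(F)c(F)cc2F)cc1`, carries 2,4,5-trifluorophenyl in place of 4-methoxyphenyl on a saturated chain carbon, two bonds along the chain from an oxygen on an aromatic ring. In this assay compound 2 also stops at the limit of > 2 h. Because of the limit of > 2 h in this assay, at which 2 of the 3 values shown sit, the step that the two limits leave unreadable from compound 1 to compound 2 cannot be read. Compound 3, `Cc1nc(C)c([C@H](OC(C)(C)C)C(=O)O)c(N2CCC(C)(C)CC2)c1-c1ccc(OCCc2ccccn2)cc1`, carries pyridin-2-yl in place of 4-methoxyphenyl on a saturated chain carbon, two bonds along the chain from an oxygen on an aromatic ring; in this assay compound 3 gives 0.5 h, which amounts to an at least 4.0-fold lower number from compound 1 to compound 3 (0.60 log units; beyond the scatter) and to an at least 4.0-fold lower number from compound 2 to compound 3 (0.60 log units; beyond the scatter). Compound 4 is `Cc1nc(C)c([C@H](OC(C)(C)C)C(=O)O)c(N2CCC(C)(C)CC2)c1-c1ccc(OCCc2cccnc2)cc1`, and its change from compound 1 is pyridin-3-yl in place of 4-methoxyphenyl on a saturated chain carbon, two bonds along the chain from an oxygen on an aromatic ring. The two steps to compound 3 bear on it most, both lowering the number beyond the scatter. A downward step of similar kind is therefore expected, an at least 2.5-fold lower number from compound 1 to compound 4 (0.39 log units; beyond the scatter). For compound 4 the estimated half-life is 0.8 h, between 0.3 h and 2 h.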

Compound 4, half-life: 0.367 h
Beside the measured number, compound 4's estimate is 2.2-fold (0.34 log units) above it, within the range that was stated.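

In this assay, the drop is no longer tied to pyridin-2-yl alone: pyridin-3-yl on the same chain carbon gives an at least 5.4-fold lower number from compound 1 to compound 4 (0.73 log units; beyond the scatter) and an at least 5.4-fold lower number from compound 2 to compound 4 (0.73 log units; beyond the scatter). Exchanging one pyridine for the other gives a 1.4-fold lower number from compound 3 to compound 4 (0.13 log units; within the scatter), so this assay does not separate pyridin-3-yl from pyridin-2-yl. Among the four compounds, the short half-lives therefore go with both pyridine rings, and none of the four goes against this.

On these data alone, the full size of the steps from compound 1 and compound 2 stays unknown because these values are limits: the limit of > 2 h in this assay, at which 2 of the 4 values shown sit. Whether pyridin-4-yl or an unsubstituted phenyl would fall with the pyridines or with the two substituted phenyl rings stays open.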